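A few compounds are considered here, and "the series" means these few. Any claim that something is new, unique, unknown or untested is made for them only; others in the source may bear on it.

Measured compounds:
compound 1, `N#Cc1ccc(Nc2ncnc(OC3C4COCC3CN(C(=O)OC3CCC3)C4)c2F)c(Cl)c1`: 10 nM
compound 2, `CC1(OC(=O)N2C[C@H]3COC[C@@H](C2)[C@@H]3Oc2ncnc(Nc3c(F)cccc3F)c2F)CC1`: 13 nM

In a functional assay on HEK293 cells for agonist activity at Glucose-dependent insulinotropic receptor (Homo sapiens), read by cAMP accumulation, with a stated time of 30 min (a higher number here means that more compound is needed for the effect, a lower number that less compound is needed), compound 1 gives 10 nM, the lowest of the two numbers recorded; compound 2 gives 13 nM in this assay, and the gap between the two lies within the scatter, so they cannot be ranked against each other.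

Compound 3, `CC1(OC(=O)N2CC3COCC(C2)C3Oc2ncnc(Nc3ccc(C#N)cc3Cl)c2F)CCC1`, has not been measured in this assay. Against compound 1 it differs by methyl in place of hydrogen on a saturated ring carbon. Cut one bond further out, the change reads cyclobutyl to 1-methylcyclobutyl. Among the compounds with values here, compound 2 carries the same 1-methylcyclobutyl carbamate but a different substituted aniline, so no single-change step between measured compounds is available for this change, and the near-equal numbers of compound 1 and compound 2 give no sign that the carbamate substituent moves the read-out much.

Compound 3 is therefore expected to give about 10 nM, with a range from 4 nM to 25 nM. The estimated step of no change at the digits printed from compound 1 to compound 3 (within the scatter) is expected to stay within the scatter, in no clear direction.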

Compound 3, half-maximal effective concentration: 10 nM
Compound 3: middle estimate and measured number agree at the digits printed; the range from low to high includes it.
By their numbers in this assay, from the lowest: compounds 1, 3 and 2 (each within the scatter of the next).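

In this assay, methyl in place of hydrogen on a saturated ring carbon of the four-membered non-aromatic ring gives no change at the digits printed from compound 1 to compound 3 (within the scatter) and is the only single-change step among the compounds shown. With the substituted aniline and the rest of the core held fixed, cyclobutyl to 1-methylcyclobutyl therefore leaves the read-out unchanged within the scatter, which compound 1 and compound 2 could not show on their own because they differ in more than one place. Nothing measured here offers an explanation for this flat step.

From the compounds shown here alone, the step rests on a single methyl on a single aniline, so what an ethyl group, a hydroxymethyl group or an amine on the same ring carbon would do remains open. Also open is whether cyclobutyl to 1-methylcyclobutyl would read the same way with the aniline of compound 2, since that compound has no cyclobutyl partner among those shown.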